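This account rests on a few compounds, and the source may have more. Where it says the series, first, only, none or still open, it means among the compounds named here.

Measured compounds:
compound 1 `O=C(O)c1ccn(Cc2cc(Br)ccc2OCc2ccccc2)n1`: 55 nM
compound 2 `Cc1cc(C(=O)O)nn1Cc1cc(Br)ccc1OCc1ccc(Cl)cc1Cl`: 0.49 nM

In a functional assay on CHO-K1 cells for antagonist activity at prostaglandin E2 receptor EP1 subtype (Homo sapiens), read by FLIPR (on this read-out lower numbers stand for stronger inhibition and higher numbers for weaker inhibition), compound 2 gives 0.49 nM, the lowest of the two numbers, and compound 1 gives 55 nM, a higher number well beyond the usual scatter. Compound 3 `Cc1cc(C(=O)O)nn1Cc1cc(Br)ccc1OCc1cccc([N+](=O)[O-])c1` is not yet measured. It differs from compound 2 in one place: 3-nitrophenyl in place of 2,4-dichlorophenyl on a saturated chain carbon bound to an oxygen on an aromatic ring. Going by the values given here, no measured pair shows a change of this kind, so the size of the step is uncertain; a moderate move toward a higher number is expected in this assay, namely a 10-fold higher number from compound 2 to compound 3 (1.01 log units; beyond the scatter). Compound 3 is estimated at 5 nM, with a range from 1 nM to 30 nM.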

Compound 3, inhibition constant: 339 nM
Beside the measured number, compound 3's estimate is 68-fold (1.83 log units) below it, and the stated range ends below it.
By their numbers in this assay, from the lowest: compound 2; then compound 1; then compound 3.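

Swapping in 3-nitrophenyl for 2,4-dichlorophenyl on this saturated chain carbon gives a 690-fold higher number from compound 2 to compound 3 (2.84 log units; beyond the scatter) in this assay and so shows that the result depends strongly on which substituted phenyl sits at this position, something no earlier pair could reveal. Nothing at hand says why the number rises so far.

With only this one swap shown, it stays open whether losing the chlorines or gaining the nitro group matters more. A phenyl carrying a methoxy group or a nitrile here could help separate the two.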